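Longer Sulfur Chain on a Shared Core: Tolerance Expected

The source may hold more compounds than are shown below. What is called first, only, known or untested is meant among the compounds shown, and "the series" means these compounds.

In an ADME assay on Akata cells (Homo sapiens) for cytotoxicity, with a stated time of 7 days (a lower number here means that less compound is tolerated, a higher number that more compound is tolerated), compound 2 `CSc1nc(N)nc2c1ncn2/C=C1/CC1(CO)CO` gives > 20000 nM, a limit of the assay rather than a number. Compound 1 `CNc1nc(N)nc2c1ncn2/C=C1/CC1(CO)CO` gives > 24000 nM in this assay, again a limit. Going by the values given here, the only measured step, a step that the two limits leave unreadable from compound 1 to compound 2, therefore cannot be read, since one value sits at the limit of > 20000 nM in this assay, at which 1 of the 2 values shown sits, and the other at the limit of > 24000 nM in this assay, at which 1 of the 2 values shown sits.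

Compound 3 `CCCCSc1nc(N)nc2c1ncn2/C=C1/CC1(CO)CO` differs from compound 2 by propyl in place of hydrogen on a saturated chain carbon bound to a sulfur. Among the compounds with values here, no measured step touches this change, and the one step that exists is unreadable, so the expectation rests on compound 2 alone. The estimate is that compound 3 stays near where compound 2 stands, with the step of an at least 1.3-fold lower number from compound 2 to compound 3 (0.12 log units; that floor lies within the scatter) expected to lie within the scatter. Compound 3 is thus expected at 15000 nM in this assay, within a range from 3000 nM to 60000 nM, with a fair chance that only a limit is reported.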

Compound 3, half-maximal cytotoxic concentration: > 20000 nM
Compound 3 gave a limit, no number (the forecaster's own chance of this, stated with the estimate: 50%); at least 1.3-fold (0.12 log units) between middle value and limit.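

Going by these compounds alone, compound 3 also gives only a limit of the assay, so no step linking compound 1, compound 2 and compound 3 can be read. The compounds shown leave open the concentration at which each becomes half-maximally cytotoxic in this assay, and whether methylsulfanyl and butylsulfanyl differ at all.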